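A Second Hydroxy on a Flat Series

The compounds below may be only part of what the source reports. "The series", "measured", "known", "first", "only" and "open" are said of these compounds alone.

Of the compounds shown here, three sharing one core have been measured so far. In a functional assay on COLO 205 cells (Homo sapiens) for inhibition, read by sulforhodamine B assay (on this read-out higher numbers stand for weaker inhibition of growth and lower numbers for stronger inhibition of growth), compound 1 (`Fc1ccc(-c2ccc(-c3ccc(-c4nc5ccccc5[nH]4)cc3)cc2)cc1`) gives 100000 nM and compound 2 (`FC(F)(F)Oc1ccc(-c2ccc(-c3ccc(-c4nc5ccccc5[nH]4)cc3)cc2)cc1`) gives 100000 nM while compound 3 (`Oc1ccc(-c2ccc(-c3ccc(-c4nc5ccccc5[nH]4)cc3)cc2)cc1`) gives 100000 nM on the same measure. Compound 3 therefore stands level with the other two.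

Compound 4 (`Oc1ccc(-c2ccc(-c3ccc(-c4nc5c(O)cccc5[nH]4)cc3)cc2)cc1`) keeps everything in compound 3 and adds hydroxy in place of hydrogen on an aromatic carbon. The change is hydroxy in place of hydrogen on an aromatic carbon and it falls on a six-membered aromatic ring of carbon only, part of a fused or bridged system of two rings.

The measured steps are no change at the digits printed from compound 1 to compound 2 (within the scatter) then no change at the digits printed from compound 1 to compound 3 (within the scatter) and finally no change at the digits printed from compound 2 to compound 3 (within the scatter) with none of them altering this ring. They show a flat series but offer no direct test of the new hydroxy.

The estimated move is a 1.3-fold lower number from compound 3 to compound 4 (0.10 log units; within the scatter) in this assay and no step beyond the scatter is expected. Compound 4 is expected near 80000 nM as an estimate, with an expected range from 20000 nM to 100000 nM on this read-out.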

Compound 4, concentration for 50% growth inhibition: 2600 nM
Compound 4: the middle estimate sits 31-fold (1.49 log units) above what was measured; the whole stated range lies above it.
By their numbers in this assay, from the lowest: compound 4; then compounds 1, 2 and 3 (each within the scatter of the next).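

In this assay, hydroxy in place of hydrogen on an aromatic carbon of the fused two-ring system brings a 38-fold lower number from compound 3 to compound 4 (1.59 log units; beyond the scatter) and is the only step beyond the scatter among the compounds shown. The steps among compounds 1, 2 and 3 all altered a different position and left the number unchanged at the digits printed, so this position is the only one shown where a change moves the growth-inhibition read-out. Nothing measured here accounts for the gain.

The compounds shown leave open whether hydroxy itself is needed on this carbon, or whether a methoxy group or an amine there would do the same. They also leave open whether the gain depends on the hydroxy already present in compound 3 or would persist with fluoro or trifluoromethoxy in its place.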